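Series notes: the step to 2-chlorophenyl

This account rests on a few compounds, and the source may have more. Where it says the series, first, only, none or still open, it means among the compounds named here.

Values from a functional assay on NRK-49F cells (Rattus norvegicus) for cytotoxicity, read by MTT assay, with a stated time of 24 h (a lower number here means a stronger inhibitor, a higher number a weaker inhibitor), are as follows
compound 1 `C/C(=N\NC(=O)/C(C#N)=C/c1ccccc1)c1c(O)c2ccc(O)cc2oc1=O` gives 55500 nM
compound 2 `C/C(=N\NC(=O)/C(C#N)=C/c1ccccc1[N+](=O)[O-])c1c(O)c2ccc(O)cc2oc1=O` gives 68600 nM
compound 3 `C/C(=N\NC(=O)/C(C#N)=C/c1cccc(Br)c1)c1c(O)c2ccc(O)cc2oc1=O` gives 59400 nM

Compound 3 stands with no separation beyond the scatter from the other two (a 1.1-fold higher number from compound 1 to compound 3 (0.03 log units; within the scatter) and a 1.2-fold lower number from compound 2 to compound 3 (0.06 log units; within the scatter)). Compound 4 `C/C(=N\NC(=O)/C(C#N)=C/c1ccccc1Cl)c1c(O)c2ccc(O)cc2oc1=O` follows, with 2-chlorophenyl in place of 3-bromophenyl on a double-bonded chain carbon bound to a double-bonded chain carbon. For the measured compounds named here, no compound with 2-chlorophenyl has been measured. Going by the values given here, the steps that bear on this change are those two and also a 1.2-fold higher number from compound 1 to compound 2 (0.09 log units; within the scatter) as a third, and none leaves the scatter. In this assay no step beyond the scatter is therefore expected, and the expected step is small (a 1.0-fold higher number from compound 3 to compound 4 (0.00 log units; within the scatter)). Compound 4 is estimated at 60000 nM (expected range 40000 nM to 90000 nM).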

Compound 4, half-maximal inhibitory concentration: 55900 nM
Compound 4: middle estimate off by 1.1-fold (0.03 log units), on the high side, and the stated range covers the measured number.
By their numbers in this assay, from the lowest: compounds 1, 4, 3 and 2 (each within the scatter of the next).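

In this assay the 2-chlorophenyl group on a double-bonded chain carbon bound to a double-bonded chain carbon does not separate from any earlier compound (a 1.1-fold lower number from compound 3 to compound 4 (0.03 log units; within the scatter); a 1.2-fold lower number from compound 2 to compound 4 (0.09 log units; within the scatter); a 1.0-fold higher number from compound 1 to compound 4 (0.00 log units; within the scatter)). Chloro thus joins nitro and bromo as a replacement for hydrogen on an aromatic carbon with no step beyond the scatter, and swapping chloro for nitro leaves none either. No measurement at hand bears on why these steps stay so small. From the compounds shown here alone, whether an amine or a carboxylic acid on the aromatic ring would give a step beyond the scatter remains open.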